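This account rests on a few compounds, and the source may have more. Where it says the series, first, only, none or still open, it means among the compounds named here.

Among the measured compounds shown here, in a physicochemical assay for lipophilicity, at pH 7.4 (on this read-out lower numbers stand for lower lipophilicity and higher numbers for higher lipophilicity), only two compounds have numbers so far. Compound 1 `C[C@H]1C(=O)N(C)C=Cc2cc(CN3CCCC3)ccc21` gives 1.5, while compound 2 `CCS(=O)(=O)c1ccc2c(c1)C(C)=CN(C)C(=O)[C@@H]2C` gives 3.4. Compound 2 therefore holds the higher of the two numbers, and the gap between them lies beyond the usual scatter of repeated measurements.

Compound 3 `CCS(=O)(=O)c1ccc2c(c1)C(c1cnn(C)c1)=CN(C)C(=O)[C@@H]2C` departs from compound 2 in one place: 1-methyl-1H-pyrazol-4-yl in place of methyl on a double-bonded ring carbon. Here, 1-methyl-1H-pyrazol-4-yl stands in place of methyl on a double-bonded ring carbon of the seven-membered non-aromatic ring, two ring bonds from the ring nitrogen.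

For the measured compounds named here, no measured pair shows this exchange or any other change confined to one place, so the expectation rests on the structural change alone and remains uncertain. A small downward move is expected, one that would not go beyond the scatter. The estimated change is a number 0.20 log units lower from compound 2 to compound 3 (within the scatter). The expectation therefore stays close to compound 2 at 3.4. In this assay, the estimate for compound 3 is 3.2, with an expected range from 2.7 to 3.7.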

Compound 3, distribution coefficient: 2.8
Estimate against measurement, compound 3: 0.40 log units above; the measured number falls inside the stated range.
By their numbers in this assay, from the lowest: compound 1; then compound 3; then compound 2.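

Among the compounds shown here, at the double-bonded ring carbon of the seven-membered non-aromatic ring, two ring bonds from the ring nitrogen, exchanging methyl for 1-methyl-1H-pyrazol-4-yl gives the first one-place step in this assay, namely a number 0.60 log units lower from compound 2 to compound 3 (beyond the scatter), and so shows that the read-out responds to what sits on this carbon. The exchange replaces a group of 1 heavy atom with one of 6 heavy atoms, bringing in a five-membered aromatic ring with 2 hetero atoms and 2 hydrogen-bond acceptors, while the molecule still carries no net charge and the count of hydrogen-bond donors stays at 0. Nothing measured here explains why the number moves as it does.

This single pair cannot separate the contribution of the aromatic ring from that of its nitrogens or its methyl group, so a phenyl ring, a pyridine, an unsubstituted pyrazole or a longer chain such as propyl on the same carbon would be needed to place the step in context. As far as these compounds go, it also remains open whether the same exchange would give a step of similar size on the core of compound 1.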